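Cyclobutyl in place of methyl: working notes on compound 4

The compounds below may be only part of what the source reports. "The series", "measured", "known", "first", "only" and "open" are said of these compounds alone.

In a physicochemical assay for acid dissociation, compound 3 (`CCN1C(=O)CN(Cc2ccc(-c3ccc(F)c(CN4CCCCC4)n3)cc2)C1=O`) gives 8.5 and stands level with compound 1 (`O=C1CN(Cc2ccc(-c3ccc(F)c(CN4CCCCC4)n3)cc2)C(=O)N1CC1CC1`) at 8.5 and within the scatter of compound 2 (`CC(C)CN1C(=O)CN(Cc2ccc(-c3ccc(F)c(CN4CCCCC4)n3)cc2)C1=O`) at 8.6 on these numbers. The change to compound 4 (`O=C1CN(Cc2ccc(-c3ccc(F)c(CN4CCCCC4)n3)cc2)C(=O)N1CC1CCC1`) is cyclobutyl in place of methyl on a saturated chain carbon bound to an amide-type nitrogen in a ring and reads as ethyl to cyclobutylmethyl when cut one bond further out. Three measured steps at the same place bear on it: a number 0.10 log units higher from compound 1 to compound 2 (within the scatter) and a number 0.10 log units lower from compound 2 to compound 3 (within the scatter) and no change at the digits printed from compound 1 to compound 3 (within the scatter) with none beyond the scatter. Among the measured compounds shown here, no cyclobutyl compound has a measured value yet. A step beyond the scatter is therefore not expected in this assay and the expected step is no change at the digits printed from compound 3 to compound 4 (within the scatter) on this reasoning. For compound 4 the estimated value is 8.5 with an expected range from 8.2 to 8.8 in this measurement.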

Compound 4, acid dissociation constant: 8.6
Compound 4: middle estimate off by 0.10 log units, on the low side; the range from low to high includes it.
By their numbers in this assay, from the lowest: compounds 1, 3, 2 and 4 (each within the scatter of the next).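

With cyclobutyl on a saturated chain carbon bound to an amide-type nitrogen in a ring, this assay gives a number 0.10 log units higher from compound 3 to compound 4 (within the scatter) and no change at the digits printed from compound 2 to compound 4 (within the scatter) and a number 0.10 log units higher from compound 1 to compound 4 (within the scatter). A four-membered carbon ring of 4 heavy atoms in place of methyl therefore still gives no step beyond the scatter at this place, now across four carbon-only groups. No supporting data bear on the reason for this result.

On these data alone, whether an amine or a carboxylic acid at this place would give a step beyond the scatter stays open. So does the outcome of any change elsewhere on the shared core.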